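This account rests on a few compounds, and the source may have more. Where it says the series, first, only, none or still open, it means among the compounds named here.

Measured in an ADME assay on a cell-free system (plasma, Homo sapiens) for protein binding, read by LC-MS, with a stated time of 5 h, tested at 5 uM:
- Compound 1 `CNC(=O)c1cc(S(=O)(=O)N2CCS[C@H]2C(=O)O[C@@H](Cc2c(Cl)c[n+]([O-])cc2Cl)c2ccc(OC(F)F)c(OCC3CC3)c2)cn1C`: 99.8%
- Compound 2 `CN(C)C(=O)c1cccc(S(=O)(=O)N2CSC[C@H]2C(=O)O[C@@H](Cc2c(Cl)c[n+]([O-])cc2Cl)c2ccc(OC(F)F)c(OCC3CC3)c2)c1`: 99.8%
- Compound 3 `COc1ccc(S(=O)(=O)N2CCCC[C@H]2C(=O)O[C@@H](Cc2c(Cl)c[n+]([O-])cc2Cl)c2ccc(OC(F)F)c(OCC3CC3)c2)cc1C(=O)N(C)C`: 99.8%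

Compound 1 stands level with the other two compounds, with no difference at the digits shown. Compound 4 `Cn1cnc(S(=O)(=O)N2CCS[C@H]2C(=O)O[C@@H](Cc2c(Cl)c[n+]([O-])cc2Cl)c2ccc(OC(F)F)c(OCC3CC3)c2)c1` has not yet been measured. It departs from compound 1 by a group of 6 heavy atoms (4 carbon, 2 nitrogen; one five-membered aromatic ring with 2 hetero atoms) in place of a group of 10 heavy atoms (7 carbon, 2 nitrogen, 1 oxygen; one five-membered aromatic ring with 1 hetero atom), on a sulfonyl sulfur, and the incoming 1-methyl-1H-imidazol-4-yl sits on a sulfonyl sulfur.

Within the data shown here, no measured pair of compounds differs in one place only, so the effect of this change has not been observed directly. The expectation rests on the values alone: while differing from compound 1 in more than one place, compound 2 still gives 99.8%, and compound 3 gives 99.8%. A small move towards less bound compound, or none beyond the scatter, is therefore expected, and the estimated change is a 2.0-fold higher unbound fraction from compound 1 to compound 4 (0.30 log units; within the scatter). The estimate for compound 4 is 99.6%, with an expected range from 98.8% to 99.9%.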

Compound 4, plasma protein binding: 98.5%
The estimate for compound 4 lay 3.8-fold (0.57 log units) (unbound fraction) below the measured number, outside the stated range (below it).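

In this assay, the group on the sulfonyl sulfur proves able to move the read-out: exchanging the group of 10 heavy atoms for 1-methyl-1H-imidazol-4-yl gives a 7.5-fold higher unbound fraction from compound 1 to compound 4 (0.88 log units; beyond the scatter). Compound 2 and compound 3 differ from compound 1 in more than one place and stand level with it, so they gave no view of this position on its own. No supporting measurement accounts for the shift.

Among these compounds, the single step cannot separate the loss of the hydrogen-bond donor from the change of ring or the smaller group, since all of these change together. Going by these compounds, whether an amine or a carboxylic acid on the sulfonyl sulfur would move the read-out further, and whether the same exchange would act alike on the cores of compound 2 and compound 3, stays open.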